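The source may hold more compounds than are shown below. What is called first, only, known or untested is meant among the compounds shown, and "the series" means these compounds.

Working notes on the series. Compound 2 `CC1CC/C(=N\Nc2ccc(O)cc2)c2ncc(C(=O)O)c(=O)n21` gives 1300 nM in a functional assay (mast cells) for inhibition, with Rattus norvegicus as the target (a higher number here means that more compound is needed for the effect, a lower number that less compound is needed), and holds the lowest number of the three measured. Compound 1 `CC1CC/C(=N\Nc2ccccc2O)c2ncc(C(=O)O)c(=O)n21` gives 208000 nM, and the step of a 160-fold lower number from compound 1 to compound 2 (2.20 log units; beyond the scatter) is the largest in the set. Compound 3 `C[C@H]1CC/C(=N\Nc2ccc(O)cc2)c2ncc(C(=O)O)c(=O)n21` gives 26200 nM; the step of a 20-fold higher number from compound 2 to compound 3 (1.30 log units; beyond the scatter) is also beyond the scatter and rests on (the fact that one of compounds 2 and 3 is drawn with a defined configuration and the other without, at the place where they differ).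

Compound 4 `CC1CC/C(=N\Nc2ccc(CC(=O)O)cc2)c2ncc(C(=O)O)c(=O)n21` differs from compound 2 by carboxymethyl in place of hydroxy on an aromatic carbon. Within the data shown here, no measured step exchanges one group for another at this position: the step from compound 1 to compound 2 moves the hydroxy, the step from compound 2 to compound 3 changes only stereochemistry. Both show that this part of the molecule moves the numbers strongly, so a change beyond the scatter is plausible, but its direction is not determined by the data. Compound 4 is therefore expected near 4000 nM, within 700 nM to 25000 nM, an estimated step of a 3.1-fold higher number from compound 2 to compound 4 (0.49 log units; beyond the scatter).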

Compound 4, half-maximal effective concentration: 3400 nM
The estimate for compound 4 lay 1.2-fold (0.07 log units) above the measured number; measured number inside the range.
By their numbers in this assay, from the lowest: compound 2; then compound 4; then compound 3; then compound 1.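

Among these compounds, exchanging hydroxy for carboxymethyl on this aromatic carbon, para to a large group, gives a 2.6-fold higher number from compound 2 to compound 4 (0.42 log units; beyond the scatter) in this assay and is the only step here that replaces one group with another at this position. Among the compounds shown here, the position therefore accepts the longer carboxymethyl group in place of hydroxy with a modest change, so hydroxy is not the only group compatible with a number of this order, while relocating the hydroxy gave the much larger a 160-fold lower number from compound 1 to compound 2 (2.20 log units; beyond the scatter). Nothing available bears on what lies behind the new step.

Going by these compounds, it remains open whether the carboxylic acid at the end of the chain or the chain itself governs the number. An amine, a carboxylic acid set directly on the aromatic carbon, or a longer chain ending in a carboxylic acid could separate these two readings.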